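A few compounds are considered here, and "the series" means these few. Any claim that something is new, unique, unknown or untested is made for them only; others in the source may bear on it.

Measured so far in an assay on HEK293 cells for inhibition of solute carrier family 22 member 12 (Homo sapiens), read by scintillation counting, with stated times of 30 min and 15 min; on this read-out higher numbers stand for weaker inhibition and lower numbers for stronger inhibition:

compound 1, `CC(C)(Sc1ccncc1Oc1ccc(C#N)c2ccccc12)C(=O)O`: 5210 nM
compound 2, `N#Cc1ccc(Oc2cnccc2SCCCCC(=O)O)c2ccccc12`: 4220 nM
compound 3, `CN(c1cnccc1SCCCCC(=O)O)c1ccc(C#N)c2ccccc12`: 3580 nM

All three numbers sit close together. The number of compound 2 lies within the scatter of both neighbours: compound 3 is nearest, compound 1 furthest, and neither gap is beyond the scatter, so no order among the three can be read from these values.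

The step to compound 4, `N#Cc1ccc(Oc2cnccc2SCC(=O)O)c2ccccc12`, alters the acid-bearing chain on the sulfur: carboxy in place of 3-carboxypropyl on a saturated chain carbon bound to a sulfur. Among the compounds with values here, one measured step concerns the same part of the structure. It is a 1.2-fold lower number from compound 1 to compound 2 (0.09 log units; within the scatter); a change of chain branching and length at the acid-bearing chain on the sulfur left the number essentially unchanged. Compound 3 shows a different part of the molecule and gives a value within the scatter of compound 2, so it adds nothing on the chain.

Within the data shown here, only one comparison bears on the shortening, and it was flat. The expectation for compound 4 is therefore a step within the scatter, a 1.1-fold higher number from compound 2 to compound 4 (0.06 log units; within the scatter), with some widening of the range because the shortening to carboxy goes further than the measured step. The estimate for compound 4 is 4800 nM, range 1600 nM to 15000 nM.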

Compound 4, half-maximal inhibitory concentration: 6970 nM
Compound 4: the middle estimate sits 1.5-fold (0.16 log units) below what was measured; the range from low to high includes it.
By their numbers in this assay, from the lowest: compounds 3, 2, 1 and 4 (each within the scatter of the next).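

With carboxymethyl on the sulfur, the series now spans a short unbranched chain as well as a long and a branched one, and replacing 4-carboxybutyl in this assay gives a 1.7-fold higher number from compound 2 to compound 4 (0.22 log units; within the scatter). Against the branched chain, the same carboxymethyl group gives a 1.3-fold higher number from compound 1 to compound 4 (0.13 log units; within the scatter), so the shortest chain shown at this position cannot be separated from either the longest or the branched chain, and the earlier flat step between the longest and branched chains now extends to a shorter chain as well. No supporting data bear on why the number responds so little to the chain on this sulfur.

All chains compared here end in a carboxylic acid, so the compounds shown do not tell whether that acid can give way to a primary amide or a tetrazole at the chain end without a step beyond the scatter. As far as these compounds go, it also stays open whether a chain longer than 4-carboxybutyl, or one carrying a phenyl ring, would leave this narrow band of values in this assay.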